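Changing the amide side chain on a shared core

This account rests on a few compounds, and the source may have more. Where it says the series, first, only, none or still open, it means among the compounds named here.

In a functional assay on PC-3 cells (Homo sapiens) for antiproliferative activity, read by MTT assay, with a stated time of 48 h (a higher number here means a weaker inhibitor, a lower number a stronger inhibitor), compound 1 (`CCn1c(C(=O)NCCCN(C)C)ccc1C(CC)(CC)c1ccc(OCCC(O)(CC)CC)c(C)c1`) gives 2150 nM while compound 2 (`CCn1c(C(=O)Nc2cccc(C(F)(F)F)c2)ccc1C(CC)(CC)c1ccc(OCCC(O)(CC)CC)c(C)c1`) gives 23800 nM and compound 3 (`CCn1c(C(=O)NC(CC(=O)O)C(=O)OC)ccc1C(CC)(CC)c1ccc(OCCC(O)(CC)CC)c(C)c1`) gives 11200 nM as the middle number of the three. Compound 4 (`CCC(C)C(CO)NC(=O)c1ccc(C(CC)(CC)c2ccc(OCCC(O)(CC)CC)c(C)c2)n1CC`) differs from compound 3 only on the amide-type nitrogen (a group of 7 heavy atoms (6 carbon, 1 oxygen; no ring) in place of a group of 9 heavy atoms (5 carbon, 4 oxygen; no ring), on an amide-type nitrogen) where 1-(hydroxymethyl)-2-methylbutyl enters.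

Three measured steps changed that same place. The step of an 11-fold higher number from compound 1 to compound 2 (1.04 log units; beyond the scatter) is large, while a 5.2-fold higher number from compound 1 to compound 3 (0.72 log units; beyond the scatter) and a 2.1-fold lower number from compound 2 to compound 3 (0.33 log units; beyond the scatter) are modest, so the group at this place can clearly move the number. Compound 1 alone reaches 2150 nM with its 3-(dimethylamino)propyl group. The entering group does not contain that group, so a number this low is not expected for compound 4. A step beyond the scatter is therefore not expected in this assay and the direction stays uncertain. The estimated change is a 1.2-fold lower number from compound 3 to compound 4 (0.09 log units; within the scatter) on this reasoning. Compound 4 is expected at 9000 nM and estimated to fall from 3500 nM to 22000 nM when measured.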

Compound 4, half-maximal inhibitory concentration: 28400 nM
For compound 4 the middle estimate is 3.2-fold (0.50 log units) below the measured one, and the stated range ends below it.
By their numbers in this assay, from the lowest: compound 1; then compound 3; then compounds 2 and 4 (each within the scatter of the next).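

In this assay, the change on the amide-type nitrogen gives a 2.5-fold higher number from compound 3 to compound 4 (0.40 log units; beyond the scatter), so 1-(hydroxymethyl)-2-methylbutyl does not hold the number seen with the group it replaces. Two quite unlike groups also end up level, with a 1.2-fold higher number from compound 2 to compound 4 (0.08 log units; within the scatter), even though 1-(hydroxymethyl)-2-methylbutyl has no ring and 3-(trifluoromethyl)phenyl has one. The 3-(dimethylamino)propyl group of compound 1 remains alone at the low end, with a 13-fold higher number from compound 1 to compound 4 (1.12 log units; beyond the scatter).

No measurement shown accounts for these differences. From the compounds shown here alone, whether the low number of compound 1 goes with its dimethylamino group remains open; a longer chain ending in the same dimethylamino group, or a chain ending in a piperidine ring, would help to test that.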